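A few compounds are considered here, and "the series" means these few. Any claim that something is new, unique, unknown or untested is made for them only; others in the source may bear on it.

Measured so far:
- compound 1 `CCc1noc(C2CCN(c3ncnc(Nc4ccc(S(C)(=O)=O)cc4)c3[N+](=O)[O-])CC2)n1`: 10 nM
- compound 2 `CCCc1noc(C2CCN(c3ncnc(Nc4ccc(S(C)(=O)=O)cc4)c3[N+](=O)[O-])CC2)n1`: 430 nM

Among the measured compounds shown here, in a functional assay for agonist activity at Glucose-dependent insulinotropic receptor (Homo sapiens) (on this read-out lower numbers stand for an effect already at smaller amounts and higher numbers for an effect only at larger amounts of compound), compound 2 gives the highest of the two numbers; the only step to it, a 43-fold higher number from compound 1 to compound 2 (1.63 log units; beyond the scatter), is a large one, and the change there is methyl in place of hydrogen on a saturated chain carbon, two bonds along the chain from an aromatic carbon. Compound 3 `CS(=O)(=O)c1ccc(Nc2ncnc(N3CCC(c4nc(CC5CC5)no4)CC3)c2[N+](=O)[O-])cc1` is not yet measured. It differs from compound 2 by cyclopropyl in place of ethyl on a saturated chain carbon bound to an aromatic carbon; cut one bond further out, the same difference reads propyl to cyclopropylmethyl. For the measured compounds named here, the one measured step that bears on it, a 43-fold higher number from compound 1 to compound 2 (1.63 log units; beyond the scatter), shows that growing the chain on this side of the core costs much in this assay. Cyclopropylmethyl keeps the chain length of propyl while closing the outer carbons into a ring, a change no measured pair covers, so the expected step of a 1.4-fold lower number from compound 2 to compound 3 (0.16 log units; within the scatter) is small and uncertain in direction. For compound 3 the estimate in this assay is 300 nM, range 60 nM to 2000 nM.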

Compound 3, half-maximal effective concentration: 160 nM
Estimate against measurement, compound 3: 1.9-fold (0.27 log units) above; the measured number falls inside the stated range.
By their numbers in this assay, from the lowest: compound 1; then compound 3; then compound 2.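

Working notes on the chain at this position: in this assay, a 2.7-fold lower number from compound 2 to compound 3 (0.43 log units; beyond the scatter) is a modest step for cyclopropyl in place of ethyl, so the number here does not simply rise with heavy atom count, as compound 3 carries the larger group yet sits lower than compound 2. The ring does not close the whole gap, with a 16-fold higher number from compound 1 to compound 3 (1.20 log units; beyond the scatter) as a large step for cyclopropyl in place of methyl, which leaves compound 1 lowest of the three. Nothing measured accounts for the difference between the ring and the open chain.

Still open, from the compounds shown here alone, is whether a branched group such as isopropyl would sit nearer compound 1 or nearer compound 3. Going by these compounds, how a chain carrying an amine or an ether oxygen would read at this position also remains open.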